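The source may report more compounds than this note shows. Statements on the series, on what has been measured and on what is new or still open speak of the compounds shown alone.

Compound 3 `O=C(CCl)Nc1ccc(I)cc1` gives the lowest number of the three compounds in a functional assay on HT-29 cells (Homo sapiens) for antiproliferative activity, with a stated time of 48 h (a higher number here means a weaker inhibitor, a lower number a stronger inhibitor), at 9700 nM. Compound 2 `CC(C)(C)c1ccc(NC(=O)NCCCCl)cc1` gives 28000 nM in this assay, and compound 1 `O=C(NCCCCl)Nc1ccc(I)cc1` gives 90000 nM. Compound 4 `CC(C)(C)c1ccc(NC(=O)CCl)cc1` differs from compound 3 by tert-butyl in place of iodo on an aromatic carbon. The same exchange has been measured once before in this assay: a 3.2-fold lower number from compound 1 to compound 2 (0.51 log units; beyond the scatter). The other measured step, a 9.3-fold lower number from compound 1 to compound 3 (0.97 log units; beyond the scatter), alters a different part of the structure and does not bear directly on this change. A modest decrease of similar size is therefore expected for compound 4, a step of a 3.2-fold lower number from compound 3 to compound 4 (0.51 log units; beyond the scatter). Compound 4 is estimated at 3000 nM in this assay, with a likely range from 1200 nM to 7500 nM.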

Compound 4, half-maximal inhibitory concentration: 15000 nM
Beside the measured number, compound 4's estimate is 5.0-fold (0.70 log units) below it, outside the stated range (above it).
By their numbers in this assay, from the lowest: compounds 3, 4 and 2 (each within the scatter of the next, the first and the last beyond it); then compound 1.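

On the chloromethyl carbonyl core, tert-butyl in place of iodo leaves only a step within the scatter in this assay (a 1.5-fold higher number from compound 3 to compound 4 (0.19 log units; within the scatter)), so the exchange at this position does not carry over unchanged from one core to the other: the same change on two cores in this assay, a 3.2-fold lower number (0.51 log units; beyond the scatter) from compound 1 to compound 2 and a 1.5-fold higher number (0.19 log units; within the scatter) from compound 3 to compound 4, 5.0-fold (0.70 log units) apart, beyond the scatter of two such steps.
Chloromethyl in place of (3-chloropropyl)amino likewise gives a much smaller step with tert-butyl on the aromatic carbon (a 1.9-fold lower number from compound 2 to compound 4 (0.27 log units; within the scatter)) than with iodo: the same change on two cores in this assay, a 9.3-fold lower number (0.97 log units; beyond the scatter) from compound 1 to compound 3 and a 1.9-fold lower number (0.27 log units; within the scatter) from compound 2 to compound 4, 5.0-fold (0.70 log units) apart, beyond the scatter of two such steps.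
The compounds leave open whether an amine or a carboxylic acid on that aromatic carbon would follow either core's trend. They also leave open how a longer chain on the carbonyl carbon would behave.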